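Swapping a furan for a benzofuran in a weak inhibitor

A few compounds are considered here, and "the series" means these few. Any claim that something is new, unique, unknown or untested is made for them only; others in the source may bear on it.

Measured so far in a functional assay on HCT-116 cells (Homo sapiens), read by MTT assay, with a stated time of 72 h; a lower number here means a stronger inhibitor, a higher number a weaker inhibitor:
Compound 1 `C#Cc1cn([C@@H]2O[C@H](CO)[C@@H](O)[C@H]2O)c2ncnc(C)c12` gives > 20000 nM (a limit)
Compound 2 `Nc1nc2c(c(-c3ccoc3)cn2[C@@H]2O[C@H](CO)[C@@H](O)[C@H]2O)c(=O)[nH]1` gives 14200 nM (a true number)

Compound 1 stands at > 20000 nM as a limit and not a number. Going by the values given here, compound 2 at 14200 nM therefore holds the only true number so far. Compound 3 `Nc1nc2c(c(-c3cc4ccccc4o3)cn2[C@@H]2O[C@H](CO)[C@@H](O)[C@H]2O)c(=O)[nH]1` differs from compound 2 in one group (1-benzofuran-2-yl in place of furan-3-yl on an aromatic carbon). Among the compounds with values here, no measured step guides this change, so in this assay only a small shift towards stronger inhibition is expected, one that stays within the scatter. The expected move (a 1.3-fold lower number from compound 2 to compound 3 (0.11 log units; within the scatter)) is modest. Compound 3 is estimated at 11000 nM (expected range 3500 nM to 20000 nM).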

Compound 3, half-maximal inhibitory concentration: > 100000 nM
Compound 3 was reported as a limit; the forecaster's own chance of this, stated with the estimate: 30%; middle value at least 9.0-fold (0.95 log units) away from the limit.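

In this assay, putting 1-benzofuran-2-yl in place of furan-3-yl on this aromatic carbon gives an at least 7.0-fold higher number from compound 2 to compound 3 (0.84 log units; beyond the scatter) and removes most or all of the modest activity of compound 2. This carbon therefore does not tolerate every aromatic group. From the compounds shown here alone, the true size of the step stays unknown because compound 3 is reported only as a limit: the limit of > 100000 nM in this assay, at which 1 of the 3 values shown sits.

The data cannot separate the effect of the added benzene ring from that of the changed attachment point on the furan ring. Going by these compounds, whether furan-2-yl, phenyl or an amine on this carbon would restore activity remains open.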